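The source may report more compounds than this note shows. Statements on the series, on what has been measured and on what is new or still open speak of the compounds shown alone.

Working notes on the series. Compound 1 `Nc1scc(CN2CCN(c3cccc(F)c3)CC2)c1C(=O)c1ccc(Cl)cc1` and compound 2 `Nc1scc(CN2CCN(c3c(F)cccc3F)CC2)c1C(=O)c1ccc(Cl)cc1` share one core and differ only in the group on an amine nitrogen in a ring. In a functional assay on CHO cells with adenosine receptor A1 (Homo sapiens) as the target, read by cAMP accumulation and immunoassay, with a stated time of 6 min, tested at 0.01 uM (on this read-out lower numbers stand for a stronger effect and higher numbers for a weaker effect at the one concentration tested), compound 1 gives -18%, and compound 2 gives -12%. The step of a number 6 percentage points higher from compound 1 to compound 2 (within the scatter) is within the scatter. Among the compounds with values here, compound 2 holds the highest of the two numbers measured so far, with compound 1 nearest and within the scatter of it. Compound 3 `Nc1scc(CN2CCN(c3ccc(Cl)c(Cl)c3)CC2)c1C(=O)c1ccc(Cl)cc1` is not yet measured; it differs from compound 2 by 3,4-dichlorophenyl in place of 2,6-difluorophenyl on an amine nitrogen in a ring. Within the data shown here, the only measured step bearing on this change is the one from compound 1 to compound 2, which also swaps one phenyl group for another on an amine nitrogen in a ring and stayed within the scatter. No step beyond the scatter is therefore expected in this assay for compound 3, whose value is estimated at -14%, between -28% and 2%. The implied step a number 2 percentage points lower from compound 2 to compound 3 (within the scatter) is expected to stay within the scatter.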

Compound 3, a percentage reported as activity, at one concentration (the size of the read-out at that concentration, not a potency): -1.2%
Compound 3: middle estimate off by 12.8 percentage points, on the low side; the range from low to high includes it.
By their numbers in this assay, from the lowest: compounds 1 and 2 (each within the scatter of the next); then compound 3.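

In this assay, 3,4-dichlorophenyl on the amine nitrogen in a ring gives a number 10.8 percentage points higher from compound 2 to compound 3 (beyond the scatter) and also a number 16.8 percentage points higher from compound 1 to compound 3 (beyond the scatter) against the 3-fluorophenyl analogue, so compound 3 shows the weakest effect of the three at the one concentration tested. The position therefore does respond to the choice of substituted phenyl group, which a number 6 percentage points higher from compound 1 to compound 2 (within the scatter) alone did not show. The groups match in heavy-atom count, ring type, hydrogen-bond donors and acceptors, and charge, and they differ in their halogen atoms and substitution pattern, but nothing on hand bears on the reason for the step.

Halogen identity and substitution pattern change together here, so which of them accounts for the step remains open. As far as these compounds go, how a methoxyphenyl or pyridyl group would read at this position is also open.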